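This account rests on a few compounds, and the source may have more. Where it says the series, first, only, none or still open, it means among the compounds named here.

Working notes on the series. Compound 1 `CCn1c(NC(C)C)nc2c(C3CCNCC3)csc2c1=O` carries a piperidin-4-yl group on the shared core; in an assay on cells for inhibition of high affinity 3',5'-cyclic-AMP phosphodiesterase 7A (Homo sapiens), read by scintillation counting and cAMP accumulation, with a stated time of 30 min (on this read-out lower numbers stand for stronger inhibition and higher numbers for weaker inhibition), compound 1 gives 190 nM. Among the three measured compounds this places compound 1 second highest. Compound 3 `CCn1c(NC(C)(C)C)nc2ccsc2c1=O` differs from compound 1 in more than one place and lacks the piperidin-4-yl group; in this assay compound 3 gives 1500 nM, the nearest number to compound 1 and a higher one beyond the scatter. For the measured compounds named here, compound 2 `CCn1c(NC(C)C)nc2c(C3CCN(c4ccccn4)CC3)csc2c1=O` gives 6.8 nM in this assay, the furthest number from compound 1; the single measured step, a 28-fold lower number from compound 1 to compound 2 (1.45 log units; beyond the scatter), is large and lies well beyond the scatter.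

Compound 4 `CCn1c(NC(C)C)nc2c(-c3cncnc3)csc2c1=O` differs from compound 1 in one place: pyrimidin-5-yl in place of piperidin-4-yl on an aromatic carbon. The step from compound 1 to compound 2 bears on this only in part: there the piperidine ring stayed and an aromatic ring was added on its nitrogen, here the ring itself is exchanged for an aromatic one. Going by the values given here, no measured step covers such an exchange. The expectation is therefore a step of moderate size toward a lower number in this assay, a 1.9-fold lower number from compound 1 to compound 4 (0.28 log units; within the scatter), with wide uncertainty. For compound 4 the estimate in this assay is 100 nM, ranging from 20 nM to 500 nM.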

Compound 4, half-maximal inhibitory concentration: 7.6 nM
Compound 4: the middle estimate sits 13-fold (1.12 log units) above what was measured; measured number below the stated range.
By their numbers in this assay, from the lowest: compounds 2 and 4 (each within the scatter of the next); then compound 1; then compound 3.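

For the compounds shown here, at this place, on an aromatic carbon of a five-membered aromatic ring with 1 sulfur, the saturated ring need not stay: exchanging piperidin-4-yl for pyrimidin-5-yl gives a 25-fold lower number from compound 1 to compound 4 (1.40 log units; beyond the scatter) in this assay, a step the earlier compounds did not cover. Two different changes at this one place now lead to low numbers, since compound 2 gives 6.8 nM with a pyridin-2-yl group on the piperidine nitrogen and compound 4 gives 7.6 nM with a single aromatic ring attached directly, and these two values lie within the scatter of each other. Nothing at hand accounts for the size of the step from compound 1 to compound 4, so the result stands as an observation without an explanation.

The compounds shown do not separate the effect of an aromatic ring as such from that of its ring nitrogens, and a phenyl or pyridin-3-yl group at this place would bear on that question. Also open, from the compounds shown here alone, is how much the aromatic character of the group on the piperidine nitrogen counts in compound 2, which an acetyl or methyl group on that nitrogen would help to test.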